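Swapping a Methoxy for a Trifluoromethyl on the Aryl Piperazine

The source may report more compounds than this note shows. Statements on the series, on what has been measured and on what is new or still open speak of the compounds shown alone.

Measured compounds:
- Compound 1, `CC1(c2ccccc2)CC(=O)N(CC(=O)N2CCN(c3cccc(Cl)c3)CC2)C1=O`: 300 mg/kg
- Compound 2, `COc1cccc(N2CCN(C(=O)CN3C(=O)CC(C)(c4ccccc4)C3=O)CC2)c1`: "not active" (no number reported)
- Compound 3, `CC1(c2ccccc2)CC(=O)N(CC(=O)N2CCC(Cc3ccccc3)CC2)C1=O`: 300 mg/kg

All three share the same core and differ only in the group carried on the amide nitrogen. In a functional assay on the whole organism (strain CD-1) with Mus musculus as the target, in the maximal electroshock model, with a stated time of 2 h (on this read-out higher numbers stand for an effect only at larger amounts of compound and lower numbers for an effect already at smaller amounts), compound 1 gives 300 mg/kg and compound 3 gives 300 mg/kg; the two numbers lie within the usual scatter of each other. Compound 2 is the odd one: in this assay compound 2 is reported as "not active" (no number reported), so no number is available for it, and it cannot be placed on the scale at all.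

Compound 4, `CC1(c2ccccc2)CC(=O)N(CC(=O)N2CCN(c3cccc(C(F)(F)F)c3)CC2)C1=O`, has not been tested. It differs from compound 2 in one place: trifluoromethyl in place of methoxy on an aromatic carbon. Compound 1 carries a chloro at the same place and does give a measurable dose, whereas compound 2 with methoxy does not. With only these points to go on, compound 4 is expected to behave more like compound 1 than like compound 2 in this assay, showing an effect at a dose similar to that of compound 1, though the chance remains that it, too, comes out without a number.

Compound 4 is estimated at 300 mg/kg, in the range 100 mg/kg to 600 mg/kg.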

Compound 4, minimum effective dose: 300 mg/kg
Compound 4: middle estimate and measured number agree at the digits printed; the range from low to high includes it.
By their numbers in this assay, from the lowest: compounds 1, 3 and 4 (each within the scatter of the next).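

In this assay, trifluoromethyl in place of chloro on this aromatic carbon gives no change at the digits printed from compound 1 to compound 4 (within the scatter), so two different groups at this position now yield a measurable dose, and a second one confirms that chloro is not unique in doing so. Methoxy in compound 2 is now the only one of the three groups here without a number, so its gap to compound 4 has no size that can be read, only the contrast between a dose and "not active". No measured property in hand accounts for why methoxy stands apart from the other two groups.

Still open, going by these compounds, is whether an amine, a carboxylic acid or a plain methyl at this position would give a number or none. Also open, on these data alone, is whether any group on this ring can bring the effect down to a smaller dose.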